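Swapping a Branched Chain for Benzyl on a Shared Core

This account rests on a few compounds, and the source may have more. Where it says the series, first, only, none or still open, it means among the compounds named here.

Compound 1 `CC(C)(C)CCn1nc(-c2cccs2)c(O)c(C2=NS(=O)(=O)c3cc(OCC(N)=O)ccc3N2)c1=O`: 0.35 h
Compound 2 `CC(C)(F)CCn1nc(-c2cccs2)c(O)c(C2=NS(=O)(=O)c3cc(OCC(N)=O)ccc3N2)c1=O`: 0.65 h
Compound 3 `CCC(C)(C)Cn1nc(-c2cccs2)c(O)c(C2=NS(=O)(=O)c3cc(OCC(N)=O)ccc3N2)c1=O`: > 1 h, a limit of the assay rather than a number

In an in vitro ADME assay on microsomes from liver (Homo sapiens) for metabolic stability (on this read-out higher numbers stand for a longer-lived compound and lower numbers for a shorter-lived compound), compound 1 gives 0.35 h, the lowest of the two plain numbers shown. Compound 2 sits close to it, with a 1.9-fold higher number from compound 1 to compound 2 (0.27 log units; within the scatter). Compound 3 reaches a limit of the assay (the limit of > 1 h in this assay, at which 1 of the 3 values shown sits). Among the measured compounds shown here, the step to it, an at least 2.8-fold higher number from compound 1 to compound 3 (0.45 log units; beyond the scatter), is the only change on the chain at the aromatic nitrogen that moved beyond the scatter. Compound 4 `NC(=O)COc1ccc2c(c1)S(=O)(=O)N=C(c1c(O)c(-c3cccs3)nn(Cc3ccccc3)c1=O)N2` differs from compound 1 by phenyl in place of neopentyl on a saturated chain carbon bound to an aromatic nitrogen. No measured step puts an aromatic ring in that place, so the precedent is thin; the two chain changes shown ranged from within the scatter to at least modest, both upward. Compound 4 is therefore expected to give 0.5 h, between 0.2 h and 1.2 h, a step of a 1.4-fold higher number from compound 1 to compound 4 (0.15 log units; within the scatter) that is expected to stay within the scatter.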

Compound 4, half-life: 0.383 h
Compound 4: the middle estimate sits 1.3-fold (0.12 log units) above what was measured, within the range that was stated.
By their numbers in this assay, from the lowest: compounds 1, 4 and 2 (each within the scatter of the next). At a limit, above all of these: compound 3.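

In this assay benzyl, the only aromatic ring shown at this place, leaves the half-life level with 3,3-dimethylbutyl (a 1.1-fold higher number from compound 1 to compound 4 (0.04 log units; within the scatter)) and level with the fluorinated chain (a 1.7-fold lower number from compound 2 to compound 4 (0.23 log units; within the scatter)). Against the 1,1-dimethylpropyl chain, the ring falls short (an at least 2.6-fold lower number from compound 3 to compound 4 (0.41 log units; beyond the scatter)), so among these groups only that branched chain stands apart. Compound 3 stands at a limit of the assay: (the limit of > 1 h in this assay, at which 1 of the 4 values shown sits).

The compounds shown leave open whether a pyridine ring, or a phenyl ring carrying an amine, would keep the same half-life on this saturated chain carbon.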